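Methyl for fluoro on a fused oxazole aryl series

The source may report more compounds than this note shows. Statements on the series, on what has been measured and on what is new or still open speak of the compounds shown alone.

Of the compounds shown here, three sharing a closely related core have been measured in a functional assay on the whole organism for inhibition, with Rattus norvegicus as the target, at a dose of 30 mg/kg; on this read-out lower numbers stand for less inhibition and higher numbers for more inhibition at the one dose given (going by the name of the read-out). Compound 1 `Cc1ccc(-c2nc3ncccc3o2)cc1` gives 5% in this assay. Compound 2 `Fc1ccc(-c2nc3ncccc3o2)cc1` gives 28%, and compound 3 `Fc1cccc(-c2nc3cccnc3o2)c1` gives 35%. The cores of compound 2 and compound 3 are built from the same atoms joined differently; the difference between the two cores is not broken down here. Between compound 2 and compound 1 the change is methyl in place of fluoro on an aromatic carbon, and it produced a number 23 percentage points lower from compound 2 to compound 1 (beyond the scatter). Compound 3 and compound 2 give numbers within the scatter of each other, so nothing can be said about their order, while the gap from compound 3 down to compound 1 is beyond the scatter.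

Compound 4 `Cc1cccc(-c2nc3cccnc3o2)c1` has not yet been measured in this assay. It differs from compound 3 by methyl in place of fluoro on an aromatic carbon. Going by the values given here, this is the same kind of change as the one from compound 2 to compound 1, but not the same: there the methyl stood para to a group of 9 heavy atoms, whereas here it stands meta to a group of 9 heavy atoms. The step to compound 4 is estimated as a number 22 percentage points lower from compound 3 to compound 4 (beyond the scatter), a drop of similar size to the earlier one, because the same kind of change produced a number 23 percentage points lower from compound 2 to compound 1 (beyond the scatter) in this assay. Compound 4 is thus expected to give about 13%, with a likely range from 0% to 30%.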

Compound 4, a percentage reported as inhibition, in the whole organism at one dose (the size of the read-out at that dose, not a potency): 14%
Compound 4: the middle estimate sits 1 percentage points below what was measured; the measured number falls inside the stated range.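

In this assay, putting methyl in place of fluoro on the aromatic carbon meta to a group of 9 heavy atoms gave a number 21 percentage points lower from compound 3 to compound 4 (beyond the scatter), and this step matches the earlier one on the other core: the same change on two cores in this assay, a number 23 percentage points lower (beyond the scatter) from compound 2 to compound 1 and a number 21 percentage points lower (beyond the scatter) from compound 3 to compound 4, 2 percentage points apart, within the scatter of two such steps Within these four compounds, then, the change carried over from one core to the other with a drop of much the same size, even though the two cores are joined differently and the group sits at a different place on the ring in each pair. This does not show that the change would behave the same way on any further core, and it does not explain the drop, as two pairs cannot separate the contribution of the core from that of the placement or say what in the change lowers the number.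

The compounds shown carry only fluoro or methyl on the aromatic ring, which leaves open how an amine, a carboxylic acid or a longer chain would read there. As far as these compounds go, each core also appears with a single placement of the group, so whether the two placements would give different numbers on one and the same core remains open.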